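The compounds below may be only part of what the source reports. "The series", "measured", "known", "first", "only" and "open" are said of these compounds alone.

Compound 1, `CCCc1c(OCCCCCCCCC(=O)O)ccc(C(C)=O)c1O`, gives 5.8 in a functional assay on ileum (Cavia porcellus) for inhibition of cysteinyl leukotriene receptor (Homo sapiens); on this read-out lower numbers stand for lower potency and higher numbers for higher potency (the scale is a negative logarithm). Compound 2, `CCCc1c(OCCCCCC(=O)O)ccc(C(=O)CC)c1O`, gives 6.1 in this assay. Compound 3, `CCCc1c(OCCCCCCc2nn[nH]n2)ccc(C(C)=O)c1O`, gives 7.1 in this assay.

Compound 3 stands highest of the three numbers, beyond the scatter from both others. Compound 4, `CCCc1c(OCCCCCCC(=O)O)ccc(C(C)=O)c1O`, differs from it by carboxy in place of 2H-tetrazol-5-yl on a saturated chain carbon, six bonds along the chain from an oxygen on an aromatic ring. Among the measured compounds shown here, the one measured step at this place, a number 1.30 log units higher from compound 1 to compound 3 (beyond the scatter), ran the other way and was large, and the two acids, compound 1 and compound 2, both sit low. Compound 4 is therefore expected to fall back toward them, by a number 1.10 log units lower from compound 3 to compound 4 (beyond the scatter) in this assay. The estimate for compound 4 is 6, within 5.5 to 6.6.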

Compound 4, negative logarithm of the antagonist equilibrium constant: 5.7
The estimate for compound 4 lay 0.30 log units above the measured number; the measured number falls inside the stated range.
By their numbers in this assay, from the lowest: compounds 4, 1 and 2 (each within the scatter of the next, the first and the last beyond it); then compound 3.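

Carboxy in place of 2H-tetrazol-5-yl on the same chain gives a number 1.40 log units lower from compound 3 to compound 4 (beyond the scatter) in this assay and so isolates the exchange of these two groups at this position. Carboxy in place of 2-carboxyethyl gives a number 0.10 log units lower from compound 1 to compound 4 (within the scatter) and leaves these two acids indistinguishable, so across compound 1 and compound 4 the longer acid chain offers no advantage. No measurement shown here explains the gap between the acid and 2H-tetrazol-5-yl. Going by these compounds, whether an amide or a sulfonamide at this place would match compound 3 stays open, as does the effect of a longer or shorter chain bearing 2H-tetrazol-5-yl.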